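This account rests on a few compounds, and the source may have more. Where it says the series, first, only, none or still open, it means among the compounds named here.

Compound 1 `Cn1ncc2c(NC(=O)NCc3cc(C(F)(F)F)nn3-c3ccc(C(F)(F)F)cc3)cccc21` is one of two compounds of the same urea core measured in an assay on CHO-K1 cells for antagonist activity at transient receptor potential cation channel subfamily V member 1 (Homo sapiens), read by FLIPR and calcium flux, with a stated time of 6 min; on this read-out lower numbers stand for stronger inhibition and higher numbers for weaker inhibition. Compound 1 gives 3.9 nM, the higher of the two numbers; compound 2 `Cn1ncc2c(NC(=O)NCc3cc(C(F)(F)F)nn3-c3ccc(F)c(Cl)c3)cccc21` gives 1.9 nM, and the step of a 2.1-fold lower number from compound 1 to compound 2 (0.31 log units; beyond the scatter) comes with the exchange of the aryl group on the ring nitrogen. Compound 3 `Cn1ncc2c(NC(=O)NCc3cc(C(C)(C)C)nn3-c3ccc(C(F)(F)F)cc3)cccc21` has not been measured. It differs from compound 1 at another place: tert-butyl in place of trifluoromethyl on an aromatic carbon. Among the measured compounds shown here, no measured step touches this group, since the only step seen, from compound 1 to compound 2, changes the aryl group and not the substituent on the five-membered ring. The change from compound 1 to compound 3 therefore rests on no comparison in this series, and no step beyond the scatter is expected in this assay. Compound 3 is estimated at 5 nM, with a range of 1.5 nM to 16 nM, a step of a 1.3-fold higher number from compound 1 to compound 3 (0.11 log units; within the scatter) from compound 1 that is expected to stay within the scatter.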

Compound 3, inhibition constant: 12.4 nM
For compound 3 the middle estimate is 2.5-fold (0.39 log units) below the measured one, and the stated range covers the measured number.
By their numbers in this assay, from the lowest: compound 2; then compound 1; then compound 3.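

The substituent on the aromatic carbon of the five-membered ring is not indifferent in this assay: tert-butyl in place of trifluoromethyl comes with a 3.2-fold higher number from compound 1 to compound 3 (0.50 log units; beyond the scatter). Among the compounds shown here, earlier, only the aryl group on the ring nitrogen had been seen to move the number, so this is the first sign that the other substituent on that ring matters too, even when the two groups match in heavy-atom count. Nothing available explains why the number rises with this exchange.

The compounds shown leave open where a methyl group, a cyclopropyl ring or an amine at this place would fall relative to trifluoromethyl and tert-butyl. For the compounds shown here, they also leave open whether the step holds with the 3-chloro-4-fluorophenyl group; this change is seen only with the 4-(trifluoromethyl)phenyl group.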